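Replacing a hydroxyl hydrogen with methyl on an aromatic oxygen

The source may report more compounds than this note shows. Statements on the series, on what has been measured and on what is new or still open speak of the compounds shown alone.

Of the compounds shown here, three sharing one core have been measured in a functional assay on SH-SY5Y cells (Homo sapiens) for cytotoxicity, read by MTT assay, with stated times of 8 h, 30 min and 12 h, tested at 5 uM; a higher number here means a stronger effect of the compound at the concentration tested, a lower number a weaker effect. Compound 1 `COc1ccc(CNC(=N)[C@@H]2CCC(=O)N2Cc2ccccc2)cc1` gives 19.5%. Compound 2 `N=C(NCc1ccccc1)[C@@H]1CCC(=O)N1Cc1ccccc1[N+](=O)[O-]` gives 25.3%. Compound 3 `N=C(NCc1ccc(O)cc1)[C@@H]1CCC(=O)N1Cc1ccccc1[N+](=O)[O-]` gives 30.4%, the highest of the three numbers; its separation from compound 2 lies within the scatter, while its separation from compound 1 lies beyond it. For the measured compounds named here, the one measured step between neighbours, a number 5.1 percentage points higher from compound 2 to compound 3 (within the scatter), is within the scatter.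

Compound 4 `COc1ccc(CNC(=N)[C@@H]2CCC(=O)N2Cc2ccccc2[N+](=O)[O-])cc1` differs from compound 3 in one place: methyl in place of hydrogen on an oxygen on an aromatic ring. Going by the values given here, no measured step adds or removes a methyl on an oxygen, so the closest guidance is indirect. Compound 1 carries a methoxy group and gives a lower number than compound 3, but compound 1 also lacks the nitro group, so the two differences cannot be separated. Given that the only single step measured, from compound 2 to compound 3, stayed within the scatter, the expected step of a number 5.4 percentage points lower from compound 3 to compound 4 (within the scatter) is small and downward, not clearly beyond the scatter. Compound 4 is therefore estimated at 25%, with a likely range from 14% to 36%.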

Compound 4, a percentage reported as activity, at one concentration (the size of the read-out at that concentration, not a potency): 25.4%
For compound 4 the middle estimate is 0.4 percentage points below the measured one, within the range that was stated.
By their numbers in this assay, from the lowest: compounds 1, 2, 4 and 3 (each within the scatter of the next, the first and the last beyond it).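

In this assay, for the compounds shown here, the change from 4-hydroxybenzyl to 4-methoxybenzyl gives the first direct reading at this oxygen (a number 5 percentage points lower from compound 3 to compound 4 (within the scatter)), so putting methyl in place of hydrogen here has no effect that stands clear of the scatter. Going by these compounds alone, compound 4 also gives the first single-change readings for adding a methoxy group (a number 0.1 percentage points higher from compound 2 to compound 4 (within the scatter)) and for nitro in place of hydrogen on an aromatic carbon (a number 5.9 percentage points higher from compound 1 to compound 4 (within the scatter)), and both stay within the scatter too. No supporting evidence is available to explain these numbers.

As far as these compounds go, it remains open whether a longer chain on this oxygen, or an amine in place of the hydroxy, would move the number beyond the scatter. From the compounds shown here alone, it is also open whether the change from hydroxy to methoxy reads the same on a core without the nitro group.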